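This account rests on a few compounds, and the source may have more. Where it says the series, first, only, none or still open, it means among the compounds named here.

Compound 1 `O=C(Nc1c(C(O)(C(F)(F)F)C(F)(F)F)ccc2ccccc12)C1CCC1` gives 45 nM in an assay on LtK cells with ATP-sensitive inward rectifier potassium channel 11 (Homo sapiens) as the target; a lower number here means that less compound is needed, a higher number that more compound is needed for the effect.
Compound 2 `O=C(Nc1c(C(O)(C(F)(F)F)C(F)(F)F)ccc2ccccc12)c1cccc(Br)c1` gives 80 nM in this assay.
Compound 3 `O=C(Nc1c(C(O)(C(F)(F)F)C(F)(F)F)ccc2ccccc12)c1ccc(Br)cc1` gives 47 nM in this assay.

Compound 3 has the second highest of the three numbers. Its nearest neighbour is compound 1, a 1.0-fold higher number from compound 1 to compound 3 (0.02 log units; within the scatter); its furthest is compound 2, a 1.7-fold lower number from compound 2 to compound 3 (0.23 log units; within the scatter). Both steps sit within the scatter, so the three compounds cannot be ordered. Across the series the group on the carbonyl carbon has gone from cyclobutyl to 3-bromophenyl, a 1.8-fold higher number from compound 1 to compound 2 (0.25 log units; within the scatter), and to 4-bromophenyl, without any step beyond the scatter.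

Compound 4 `O=C(Nc1c(C(O)(C(F)(F)F)C(F)(F)F)ccc2ccccc12)c1cnco1` is not yet measured in this assay. Its difference from compound 3: 1,3-oxazol-5-yl in place of 4-bromophenyl on a carbonyl carbon. Among the compounds with values here, no measured step exchanges a six-membered aromatic ring of carbon only for a five-membered aromatic ring with hetero atoms. Within the data shown here, the steps that bear on the change, cyclobutyl to 4-bromophenyl a 1.0-fold higher number from compound 1 to compound 3 (0.02 log units; within the scatter) and 3-bromophenyl to 4-bromophenyl a 1.7-fold lower number from compound 2 to compound 3 (0.23 log units; within the scatter), are both within the scatter, so no step beyond the scatter is expected in this assay. Among the measured compounds shown here, the 1,3-oxazol-5-yl ring has no precedent; the range is therefore set wider than the measured steps alone would suggest. Compound 4 is expected at 60 nM, between 22 nM and 170 nM, an expected step of a 1.3-fold higher number from compound 3 to compound 4 (0.11 log units; within the scatter).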

Compound 4, half-maximal effective concentration: 24 nM
The estimate for compound 4 lay 2.5-fold (0.40 log units) above the measured number; measured number inside the range.
By their numbers in this assay, from the lowest: compounds 4, 1, 3 and 2 (each within the scatter of the next, the first and the last beyond it).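

The carbonyl carbon accepts a five-membered aromatic ring with 2 hetero atoms in this assay: the step to 1,3-oxazol-5-yl is a 2.0-fold lower number from compound 3 to compound 4 (0.29 log units; within the scatter) from 4-bromophenyl and a 1.9-fold lower number from compound 1 to compound 4 (0.27 log units; within the scatter) from cyclobutyl, both within the scatter. Within the data shown here, only the exchange for 3-bromophenyl, a 3.3-fold lower number from compound 2 to compound 4 (0.52 log units; beyond the scatter), clears the scatter, making it the one modest step and the first sign that this position affects the number at all. No measurement bears on the reason for this step.

Open, going by these compounds, is whether this holds for other rings at this place, such as a thiazole or a pyridine. Also open, on these data alone, is whether an amine or a carboxylic acid on the ring would be accepted there.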